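A few compounds are considered here, and "the series" means these few. Any claim that something is new, unique, unknown or untested is made for them only; others in the source may bear on it.

Three compounds share the same core, an aryl-alkyne carrying the phenoxyacetic acid, and differ in the group attached to the other aromatic ring. Compound 1 `CC(C)(C)N1C(=O)c2ccc(C#Cc3cc(Cl)ccc3OCC(=O)O)cc2S1(=O)=O` carries a cyclic sulfonyl-imide, compound 2 `Cc1ccc(S(=O)(=O)Cc2ccccc2)cc1C#Cc1cc(Cl)ccc1OCC(=O)O` a benzylsulfonyl group and compound 3 `CCCS(=O)(=O)c1ccc(F)c(C#Cc2cc(Cl)ccc2OCC(=O)O)c1` a propylsulfonyl group with an added fluorine. In an assay on CHO cells for displacement of a labelled ligand from prostaglandin D2 receptor 2 (Homo sapiens), read by scintillation counting (a higher number here means a weaker inhibitor, a lower number a stronger inhibitor), compound 1 gives 14 nM, compound 2 gives 5 nM and compound 3 gives 3.4 nM. Compound 2 thus stands second highest of the three numbers: its value and that of compound 3 lie within the scatter of each other, while the number for compound 1 is beyond the scatter above it.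

Compound 4 `Cc1ccc(S(=O)(=O)N(C)CCN(C)C)cc1C#Cc1cc(Cl)ccc1OCC(=O)O` is the next step from compound 2. The change is (2-(dimethylamino)ethyl)(methyl)amino in place of benzyl on a sulfonyl sulfur. Going by the values given here, no measured pair shows this kind of change, so its effect is unknown; the only guide is that the three measured sulfonyl variants all sit in a narrow band. For compound 4 the step of a 3.0-fold higher number from compound 2 to compound 4 (0.48 log units; beyond the scatter) is expected to be a modest weakening, close to the scatter. Compound 4 is therefore estimated at 15 nM in this assay, with a range from 4 nM to 60 nM.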

Compound 4, inhibition constant: 369 nM
For compound 4 the middle estimate is 25-fold (1.39 log units) below the measured one; measured number above the stated range.
By their numbers in this assay, from the lowest: compounds 3 and 2 (each within the scatter of the next); then compound 1; then compound 4.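

In this assay, going by these compounds alone, the exchange of benzyl for (2-(dimethylamino)ethyl)(methyl)amino on a sulfonyl sulfur gives a 74-fold higher number from compound 2 to compound 4 (1.87 log units; beyond the scatter) and shows that this place is not indifferent to what it carries, a sensitivity that no earlier compound could reveal, since none formed a measured step. The leaving and entering groups hold the same number of heavy atoms, yet the step swaps an aromatic ring for an open chain and turns benzylsulfonyl into a sulfamoyl group, so these changes cannot be told apart here. Nothing given here accounts for the size of this step.

Going by these compounds, it remains open whether a benzylamino group on the same sulfur would keep the number of compound 2. On these data alone, it is equally open whether a chain ending in a hydroxyl group instead of dimethylamino would recover any of the loss.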